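The source may report more compounds than this note shows. Statements on the series, on what has been measured and on what is new or still open speak of the compounds shown alone.

Compound 1 `CS(=O)(=O)c1ccc(-c2cnc3[nH]cc(-c4nnc(-c5ccc(F)cc5)o4)c(=O)c3c2)cc1`: 8.1%
Compound 2 `CS(=O)(=O)c1ccc(-c2cnc3[nH]cc(-c4nnc(-c5ccc(Cl)cc5)o4)c(=O)c3c2)cc1`: 13.1%

In a functional assay on MCF7 cells (Homo sapiens) for inhibition, read by MTT assay, with a stated time of 24 h, tested at 10 uM (a lower number here means less inhibition of growth, a higher number more inhibition of growth at the concentration tested), compound 1 gives 8.1% and compound 2 gives 13.1%. Both numbers are small, so neither compound holds back the growth of the cells to any great extent at the tested concentration. The step of a number 5 percentage points higher from compound 1 to compound 2 (within the scatter) is the only measured one, and it stays within the scatter, so compound 2 cannot be told apart from compound 1 on this assay; compound 2 simply sits at the upper of two closely spaced numbers.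

Compound 3 `Cc1cccc(-c2nnc(-c3c[nH]c4ncc(-c5ccc(S(C)(=O)=O)cc5)cc4c3=O)o2)c1` carries the change (3-methylphenyl in place of 4-chlorophenyl on an aromatic carbon). Going by the values given here, no measured step bears directly on this swap: the one step available, a number 5 percentage points higher from compound 1 to compound 2 (within the scatter), exchanges one halogen for another on the same ring and produced no change beyond the scatter. With the shared core unchanged and both measured compounds showing little inhibition, the expected step of a number 1.1 percentage points lower from compound 2 to compound 3 (within the scatter) is none beyond the scatter. Compound 3 is therefore estimated at 12%, with a range from 2% to 24%.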

Compound 3, percent growth inhibition at one concentration: 7.76%
Compound 3: the middle estimate sits 4.2 percentage points above what was measured; measured number inside the range.
By their numbers in this assay, from the lowest: compounds 3, 1 and 2 (each within the scatter of the next).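

Moving from a halogen on the outer phenyl ring to a methyl group, with the substituent also at a different ring position, gives a number 5.3 percentage points lower from compound 2 to compound 3 (within the scatter) and a number 0.3 percentage points lower from compound 1 to compound 3 (within the scatter) in this assay. The earlier step only exchanged one halogen for another at the same ring position, so this result extends the picture: on this aromatic carbon of the five-membered ring, 4-fluorophenyl, 4-chlorophenyl and 3-methylphenyl cannot be told apart, and all three compounds show little inhibition of growth. No separate measurement is available to explain why these numbers stay so close together.

Two things changed at once in compound 3, the kind of substituent and its place on the phenyl ring, so 4-methylphenyl would be needed to separate them. On these data alone, it also remains open whether a quite different substituent on this ring, such as an amine, a carboxylic acid or a longer alkyl chain, would move the number beyond the scatter.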